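The source may report more compounds than this note shows. Statements on the series, on what has been measured and on what is new or still open speak of the compounds shown alone.

Measured so far:
compound 1 `N#Cc1cccc(C(=O)NC(=S)N2CCc3c(OCCCCCOc4ccc(Cl)cc4)cccc32)c1`: 9750 nM
compound 2 `O=C(NC(=S)N1CCc2c(OCCCCCOc3ccc(Cl)cc3)cccc21)c1ccc(C(F)(F)F)cc1`: 32700 nM

Both numbers come from an ADME assay on Huh-7 cells (Homo sapiens) for cytotoxicity; a higher number here means that more compound is tolerated, a lower number that less compound is tolerated. Among the compounds with values here, of the two, compound 2 stands highest, so more of it is tolerated by the cells; its only neighbour is compound 1, and the one measured step, a 3.4-fold higher number from compound 1 to compound 2 (0.53 log units; beyond the scatter), was modest yet beyond the scatter. That step, however, came from a different exchange, 4-(trifluoromethyl)phenyl in place of 3-cyanophenyl on a carbonyl carbon, so it bears only loosely on what follows.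

Compound 3 `CC(C)(C)c1ccc(C(=O)NC(=S)N2CCc3c(OCCCCCOc4ccc(Cl)cc4)cccc32)cc1` shares the core of compound 2 and differs from it in one place: tert-butyl in place of trifluoromethyl on an aromatic carbon. Within the data shown here, no measured pair shows this exchange, and the single known step concerns a different part of the ring, so there is little ground for expecting a move beyond the scatter in either direction.

Compound 3 is therefore expected to give about 25000 nM in this assay, with a likely range from 8000 nM to 80000 nM. The step this estimate implies, a 1.3-fold lower number from compound 2 to compound 3 (0.12 log units; within the scatter), is expected to fall within the usual scatter.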

Compound 3, half-maximal cytotoxic concentration: > 50000 nM
Compound 3 ended at the assay's limit; the forecaster's own chance of this, stated with the estimate: 15%; middle value at least 2.0-fold (0.30 log units) from the limit.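

In this assay compound 3 gives > 50000 nM, a limit of the assay and not a number, and the one value of this kind among those shown: the limit of > 50000 nM in this assay, at which 1 of the 3 values shown sits.

Going by these compounds, putting tert-butyl in place of trifluoromethyl on this aromatic carbon, para to a large group, gives an at least 1.5-fold higher number from compound 2 to compound 3 (0.18 log units; that floor lies within the scatter), so the data show no loss of tolerance from this exchange, while the printed floor cannot establish a real gain and the true size of the step stays unknown. The wider comparison is clearer, with an at least 5.1-fold higher number from compound 1 to compound 3 (0.70 log units; beyond the scatter), which joins a 3.4-fold higher number from compound 1 to compound 2 (0.53 log units; beyond the scatter) in showing that both 4-substituted phenyl groups shown give higher numbers than 3-cyanophenyl, and neither of the compounds carrying them goes against this.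

Still open, on these data alone, is whether those higher numbers follow from the group itself or from where it sits on the ring, and a nitrile on this same aromatic carbon would help to separate the two. Also open, as far as these compounds go, is how an amine or a carboxylic acid at this place would read in this assay.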